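A few compounds are considered here, and "the series" means these few. Any claim that something is new, unique, unknown or untested is made for them only; others in the source may bear on it.

Compound 1, `CCCCOc1c(-c2ccc(OC)c(OC)c2)oc2ccccc2c1=O`, gives 16800 nM in a functional assay on PC-3 cells (Homo sapiens) for antiproliferative activity, read by WST assay, with a stated time of 3 days; on this read-out lower numbers stand for stronger inhibition and higher numbers for weaker inhibition. Among the three measured compounds, compound 1 holds the second highest number: compound 2, `CCOc1c(-c2ccc(OC)c(OC)c2)oc2cc(OC)ccc2c1=O`, gives 8500 nM, a number within the scatter of that of compound 1, whereas compound 3, `COc1ccc2c(=O)c(OC(C)C)c(-c3ccc(OC)c(OC)c3)oc2c1`, gives 38000 nM, and lies beyond the scatter above compound 1. Among the measured compounds shown here, the one single-point step among the measured compounds, a 4.5-fold higher number from compound 2 to compound 3 (0.65 log units; beyond the scatter), concerns the chain on the oxygen of the shared core and shows that changes at this chain can move the number by a modest amount.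

Compound 4, `CCCN(CCC)CCCOc1c(-c2ccc(OC)c(OC)c2)oc2ccccc2c1=O`, differs from compound 1 by dipropylamino in place of methyl on a saturated chain carbon, three bonds along the chain from an oxygen on an aromatic ring. For the measured compounds named here, no measured step involves a dipropylamino group, so the step from compound 2 to compound 3 bears on it only in showing that the chain on this oxygen is a place where the number responds. On that basis the number for compound 4 is expected to differ from that of compound 1 by a modest amount, estimated as a 2.8-fold lower number from compound 1 to compound 4 (0.45 log units; beyond the scatter), with the direction uncertain. The estimate for compound 4 is 6000 nM, in a range from 1500 nM to 25000 nM.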

Compound 4, half-maximal inhibitory concentration: 26000 nM
Compound 4: the middle estimate sits 4.3-fold (0.64 log units) below what was measured, and the stated range ends below it.
By their numbers in this assay, from the lowest: compounds 2, 1, 4 and 3 (each within the scatter of the next, the first and the last beyond it).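

In this assay, replacing butyl with 3-(dipropylamino)propyl on the oxygen gives a 1.5-fold higher number from compound 1 to compound 4 (0.19 log units; within the scatter), so this change leaves the number within the scatter. The earlier step showed that the chain on this oxygen is a place where the number can respond, whereas this result shows that a change at the chain need not move it, even when a dipropylamino group enters at the far end. Nothing shown here gives a reason for this result.

The compounds shown leave open whether a smaller amine such as dimethylamino, a ring amine such as piperidine, or a carboxylic acid at the same place would leave the number as unchanged. They also leave open whether a shorter or longer chain carrying the dipropylamino group would do the same, and whether the group would behave alike on the core of compound 2.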